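Aryl variation on the alkyne of the shared lactam core

This account rests on a few compounds, and the source may have more. Where it says the series, first, only, none or still open, it means among the compounds named here.

Measured so far in a functional assay on HEK293 cells for negative allosteric modulation of metabotropic glutamate receptor 5 (Homo sapiens), read by FLIPR and calcium flux; a lower number here means a stronger inhibitor, a higher number a weaker inhibitor:
compound 1 `Cc1ccccc1C#Cc1ccc2c(n1)CCN(C)C2=O` gives 776 nM
compound 2 `CN1CCc2nc(C#Cc3ccc(Cl)cc3)ccc2C1=O` gives 352 nM
compound 3 `Cc1ccccc1C#Cc1ccc2c(n1)CCN(C(C)C)C2=O` gives 810 nM

Compound 3 holds the highest number of the three in this assay, though compound 1 lies within the scatter of it (a 1.0-fold higher number from compound 1 to compound 3 (0.02 log units; within the scatter)); only compound 2 is separated from it beyond the scatter.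

Compound 4 `CC(C)N1CCc2nc(C#Cc3cccnc3)ccc2C1=O` is the next step from compound 3: pyridin-3-yl in place of 2-methylphenyl on a triple-bonded carbon. The amide-nitrogen substituent differs between the two and is kept as in compound 3.

Going by the values given here, two measured steps bear on this. The swap of the nitrogen substituent, a 1.0-fold higher number from compound 1 to compound 3 (0.02 log units; within the scatter), indicates that the isopropyl end of compound 3 is a fair base. Among the compounds with values here, the only aryl swap at the same place, a 2.2-fold lower number from compound 1 to compound 2 (0.34 log units; beyond the scatter), was modest and replaced one carbocycle with another; no measured step introduces a ring hetero atom, so the direction for compound 4 cannot be read from the data. The step is therefore expected to stay within or near the scatter, a 1.2-fold higher number from compound 3 to compound 4 (0.09 log units; within the scatter), with a wide range.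

Compound 4 is estimated at 1000 nM in this assay, expected between 300 nM and 3000 nM.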

Compound 4, half-maximal inhibitory concentration: "not active" (no number reported)
Compound 4: no number reported; there is nothing to compare the estimate with.
By their numbers in this assay, from the lowest: compound 2; then compounds 1 and 3 (each within the scatter of the next).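

Going by these compounds alone, compound 4 is reported as "not active" in this assay with no number, so no step from compound 3 can be read. No available evidence bears on this result. The compounds shown leave open whether pyridin-3-yl would give a number with methyl in place of isopropyl on the amide-type nitrogen.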